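Swapping the dichlorophenyl group for a carbamoylphenyl group

The source may report more compounds than this note shows. Statements on the series, on what has been measured and on what is new or still open speak of the compounds shown alone.

Compound 1 `Cc1nc(-c2ccccc2)c(C(=O)N2CCN(c3cccc(Cl)c3Cl)CC2)o1`: 133 nM
Compound 2 `Cc1ccc(C)c(N2CCN(C(=O)c3oc(C)nc3-c3ccc(F)cc3)CC2)c1`: 358 nM

In a functional assay on HL-60 cells (Homo sapiens) for inhibition, read by MTT assay, with a stated time of 72 h (a lower number here means a stronger inhibitor, a higher number a weaker inhibitor), compound 1 gives 133 nM, the lower of the two numbers, so it is the stronger inhibitor of this pair. Compound 2, at 358 nM, lies above it by more than the usual scatter.

Compound 3 `Cc1nc(-c2ccccc2)c(C(=O)N2CCN(c3cccc(C(N)=O)c3)CC2)o1` keeps the core of compound 1 but has 3-carbamoylphenyl in place of 2,3-dichlorophenyl on an amine nitrogen in a ring. Neither measured compound carries a carbamoyl group, so the data offer no direct guide to this change. Compound 1 starts from the better of the two values, at 133 nM, so a loss seems likelier than a gain. The expected change is a moderate weakening, an estimated 5.3-fold higher number from compound 1 to compound 3 (0.72 log units; beyond the scatter). For compound 3 the estimated value is 700 nM, with an expected range of 150 nM to 3500 nM.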

Compound 3, half-maximal inhibitory concentration: 71 nM
Estimate against measurement, compound 3: 9.9-fold (0.99 log units) above, and the stated range ends above it.
By their numbers in this assay, from the lowest: compounds 3 and 1 (each within the scatter of the next); then compound 2.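

In this assay, the step of a 1.9-fold lower number from compound 1 to compound 3 (0.27 log units; within the scatter) means that the two compounds cannot be told apart. This position on the ring amine nitrogen therefore accepts a very different aryl group without a clear change in the number: 3-carbamoylphenyl, with 1 hydrogen-bond donor and 1 hydrogen-bond acceptor, takes the place of 2,3-dichlorophenyl, which has neither and carries both chlorine atoms. Nothing in the data explains why the number holds.

The compounds shown leave open whether the carbamoyl group itself matters, or whether a carboxylic acid, a nitrile or a simple amine on the same phenyl ring would give a similar number. Going by these compounds alone, with only this one step on the core of compound 1, it also remains unknown how far this tolerance extends to other groups.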